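Dichlorophenyl to Dihydroxyphenyl on a Shared Core

This account rests on a few compounds, and the source may have more. Where it says the series, first, only, none or still open, it means among the compounds named here.

Compound 1 `COc1cccc(CNc2ncnc3c2ncn3[C@@H]2O[C@H](CO)[C@@H](O)[C@H]2O)c1`: > 166000 nM in this assay, a limit rather than a number
Compound 2 `OC[C@H]1O[C@@H](n2cnc3c(NCc4ccc(Cl)c(Cl)c4)ncnc32)[C@H](O)[C@@H]1O`: 88800 nM

Of the compounds shown here, two have so far been tested in a functional assay on MCF cells (Homo sapiens) for antiproliferative activity, with a stated time of 72 h; a higher number here means a weaker inhibitor, a lower number a stronger inhibitor. Compound 1 reaches only a limit of the assay (the limit of > 166000 nM in this assay, at which 1 of the 2 values shown sits). Going by the values given here, compound 2 gives the only real number in the set, so it stands alone as the reference point. Among the compounds with values here, the single measured step, an at least 1.8-fold lower number from compound 1 to compound 2 (0.27 log units; that floor lies within the scatter), has a floor that lies within the scatter, so it neither confirms nor rules out an effect of changing the aryl group.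

Compound 3 `OC[C@H]1O[C@@H](n2cnc3c(NCc4cc(O)cc(O)c4)ncnc32)[C@H](O)[C@@H]1O` has not yet been measured. It differs from compound 2 by 3,5-dihydroxyphenyl in place of 3,4-dichlorophenyl on a saturated chain carbon bound to a nitrogen on an aromatic ring. Within the data shown here, no measured step covers this swap, and the one step available is itself inconclusive, so the expected step of a 1.1-fold higher number from compound 2 to compound 3 (0.05 log units; within the scatter) is set at essentially no change beyond the scatter, with a wide range. Compound 3 is therefore expected to give about 100000 nM, between 40000 nM and 166000 nM.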

Compound 3, half-maximal inhibitory concentration: > 166000 nM
Compound 3 ended at the assay's limit; the forecaster's own chance of this, stated with the estimate: 35%; middle value at least 1.6-fold (0.22 log units) away from the limit.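

In this assay, going by these compounds alone, compound 3 gives only a limit and not a number, which leaves compound 2 as the only compound with a real value: the limit of > 166000 nM in this assay, at which 2 of the 3 values shown sit. Exchanging the 3,4-dichlorobenzyl group for 3,5-dihydroxybenzyl gives an at least 1.8-fold higher number from compound 2 to compound 3 (0.27 log units; that floor lies within the scatter), so this swap, like the earlier change of aryl group, establishes no effect. The step between compound 1 and compound 3 cannot be read, since each of the two gives only a limit.

The compounds shown leave open what real numbers compound 1 and compound 3 would give, and so whether 3,4-dichlorophenyl truly differs from the other two groups. Also open, from the compounds shown here alone, is how a longer chain, or a carboxylic acid in place of the 3,4-dichlorobenzyl group, would behave on the shared core.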